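Trading a methoxy for a chloro on a weak cytotoxic series

The compounds below may be only part of what the source reports. "The series", "measured", "known", "first", "only" and "open" are said of these compounds alone.

Measured compounds:
Compound 1 `COc1cccc(/C=C/C(=O)c2sc(Nc3ccc(Cl)c(Cl)c3)nc2C)c1`: 8350 nM
Compound 2 `Cc1nc(Nc2cccc(Cl)c2)sc1C(=O)/C=C/c1ccc(Cl)cc1`: > 25000 nM
Compound 3 `COc1ccc(/C=C/C(=O)c2sc(Nc3ccc(Cl)c(Cl)c3)nc2C)cc1`: > 25000 nM

In a functional assay on BGC-823 cells (Homo sapiens) for cytotoxicity, read by MTT assay (a lower number here means a stronger inhibitor, a higher number a weaker inhibitor), compound 1 gives 8350 nM. For compound 3 the value is a limit of this assay, > 25000 nM. For compound 2 the value is likewise a limit, > 25000 nM. Compound 3 thus stands at the weak end of what is shown, with only a limit and no number, as does compound 2 (the limit of > 25000 nM in this assay, at which 2 of the 3 values shown sit).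

Compound 4 `Cc1nc(Nc2ccc(Cl)c(Cl)c2)sc1C(=O)/C=C/c1ccc(Cl)cc1` differs from compound 3 by one change: chloro in place of methoxy on an aromatic carbon. Within the data shown here, only one measured step exists here, an at least 2.9-fold higher number from compound 1 to compound 3 (0.47 log units; beyond the scatter), and it moves the methoxy around the ring rather than exchanging it, so it does not bear directly on the change to compound 4. Compound 2 carries the same 4-chlorophenyl and sits at the limit, but differs elsewhere too.

Among the measured compounds shown here, with no step in hand and two neighbours at the limit, compound 4 is expected to stay weak, a step that the limit leaves unreadable from compound 3 to compound 4, most likely again a limit. The estimate for compound 4 is 30000 nM, between 10000 nM and 100000 nM.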

Compound 4, half-maximal inhibitory concentration: 22700 nM
The estimate for compound 4 lay 1.3-fold (0.12 log units) above the measured number, within the range that was stated.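

With 4-chlorophenyl in place of 4-methoxyphenyl, compound 4 gives a true number in this assay, 22700 nM, which shows that a group on this ring carbon can leave a value inside the measurable range. The exchange of methoxy for chloro gives an at least 1.1-fold lower number from compound 3 to compound 4 (0.04 log units; that floor lies within the scatter), and the added chloro on the other ring gives an at least 1.1-fold lower number from compound 2 to compound 4 (0.04 log units; that floor lies within the scatter). Both steps start from a limit, so neither change can be sized: the limit of > 25000 nM in this assay, at which 2 of the 4 values shown sit. The 3-methoxyphenyl group still gives the lower number, with a 2.7-fold higher number from compound 1 to compound 4 (0.43 log units; beyond the scatter).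

On these data alone, the true values of compound 3 and compound 2 remain unknown, so the size of the methoxy-to-chloro change stays open. Also open, as far as these compounds go, is how an amine or a carboxylic acid on this same ring carbon would read, and how a chloro would read on the ring carbon that holds the methoxy in compound 1.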